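The source may hold more compounds than are shown below. What is called first, only, known or untested is meant among the compounds shown, and "the series" means these compounds.

Compound 3 `CCCCCC(=O)OCc1c(F)c(N)c2c(=O)cc(-c3ccc(N)c(F)c3)oc2c1F` gives 160 nM in a functional assay on MCF7 cells (Homo sapiens) for cytotoxicity, read by neutral red uptake, with a stated time of 3 days (on this read-out lower numbers stand for stronger inhibition and higher numbers for weaker inhibition), the highest of the three numbers measured. Compound 1 `Nc1ccc(-c2cc(=O)c3c(N)c(F)cc(F)c3o2)cc1F` gives 40 nM and compound 2 `Nc1ccc(-c2cc(=O)c3c(N)c(F)c(N)c(F)c3o2)cc1F` gives 7.7 nM; the steps to compound 3 run a 4.0-fold higher number from compound 1 to compound 3 (0.60 log units; beyond the scatter) and a 21-fold higher number from compound 2 to compound 3 (1.32 log units; beyond the scatter), while a 5.2-fold lower number from compound 1 to compound 2 (0.72 log units; beyond the scatter). Compound 4 `CCCCCC(=O)NCc1c(F)c(N)c2c(=O)cc(-c3ccc(N)c(F)c3)oc2c1F` differs from compound 3 by (pentylcarbonyl)amino in place of (pentylcarbonyl)oxy on a saturated chain carbon bound to an aromatic carbon. Among the compounds with values here, no measured step exchanges (pentylcarbonyl)oxy for (pentylcarbonyl)amino, so nothing among the measured compounds sets the size or direction of such a change; the expectation is therefore a step of a 1.1-fold higher number from compound 3 to compound 4 (0.05 log units; within the scatter), within the scatter, with the number for compound 4 staying near that of compound 3. Compound 4 is thus expected to give 180 nM, with a range from 60 nM to 500 nM.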

Compound 4, half-maximal inhibitory concentration: 340 nM
For compound 4 the middle estimate is 1.9-fold (0.28 log units) below the measured one, and the stated range covers the measured number.
By their numbers in this assay, from the lowest: compound 2; then compound 1; then compound 3; then compound 4.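

In this assay, the exchange on this saturated chain carbon bound to an aromatic carbon gives a 2.1-fold higher number from compound 3 to compound 4 (0.33 log units; beyond the scatter), so (pentylcarbonyl)amino and (pentylcarbonyl)oxy do not read alike here, though the step is modest. Set against the compounds lacking this side chain, ((pentylcarbonyl)amino)methyl gives an 8.5-fold higher number from compound 1 to compound 4 (0.93 log units; beyond the scatter) and a 44-fold higher number from compound 2 to compound 4 (1.64 log units; beyond the scatter), leaving compound 4 with the highest number of the four. Nothing available explains this difference. The compounds shown leave open how a free aminomethyl, a hydroxymethyl or a longer acyl chain on the same nitrogen would read at this place.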